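This account rests on a few compounds, and the source may have more. Where it says the series, first, only, none or still open, it means among the compounds named here.

Measured so far, in a functional assay on HeLa cells (Homo sapiens) for cytotoxicity, read by MTT assay, with a stated time of 72 h; on this read-out lower numbers stand for stronger inhibition and higher numbers for weaker inhibition:

Compound 1, `Cc1nnc(SCc2cc(=O)c3ccccc3o2)s1`, gives > 25000 nM, which is a limit of the assay rather than a number.
Compound 2, `Nc1nnc(SCc2cc(=O)c3ccccc3o2)s1`, gives > 25000 nM, again a limit of the assay.
Compound 3, `Nc1nnc(SCc2coc3ccccc3c2=O)s1`, gives > 25000 nM, also a limit of the assay.

Compound 2 and compound 1 differ by one change, (methyl in place of amino on an aromatic carbon). The step this made, a step that the two limits leave unreadable from compound 2 to compound 1, cannot be read, because the limit of > 25000 nM in this assay, at which 3 of the 3 values shown sit, holds both values. Compound 2 and compound 3 share the same atoms joined differently; the difference between the two cores is not broken down here.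

Compound 4, `Cc1nnc(SCc2coc3ccccc3c2=O)s1`, has not yet been measured in this assay. It is related to compound 3 by methyl in place of amino on an aromatic carbon, the same change that turns compound 2 into compound 1, at a place described in the same words. Among the compounds with values here, since every value so far sits at the limit, the expected step that the limit leaves unreadable from compound 3 to compound 4 from compound 3 to compound 4 is no more than a guess. Compound 4 is expected to give about 30000 nM, most likely again reported only as a limit, within 10000 nM to 100000 nM.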

Compound 4, half-maximal inhibitory concentration: 2300 nM
Compound 4: middle estimate off by 13-fold (1.12 log units), on the high side; measured number outside the range, below it.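

In this assay, methyl in place of amino on the core of compound 3 gives an at least 10-fold lower number from compound 3 to compound 4 (1.03 log units; beyond the scatter), a large step whose size is a minimum, since compound 3 starts from a limit of the assay. Compound 1 gives > 25000 nM, which is a limit and not a number, so on its core the same change brought no readable value. This shows that the drop seen with compound 4 did not carry over in readable form, but it does not show that the change does nothing on that core, as the step from compound 2 to compound 1 cannot be read, because both values sit at the limit: the limit of > 25000 nM in this assay, at which 3 of the 4 values shown sit.

The compounds shown leave open whether the lower number with compound 4 depends on methyl itself or simply on amino being gone. From the compounds shown here alone, an ethyl group or a carboxylic acid at the same place on the core of compound 4 would help to tell these apart, and other cell types remain open too.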